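Chloro for Bromo: A Second Halogen Swap Forecast

The source may report more compounds than this note shows. Statements on the series, on what has been measured and on what is new or still open speak of the compounds shown alone.

Three compounds share one core and differ only in which halogen they carry and where it sits. Compound 1 `COC(=O)[C@@]1(C)CCC=C2[C@@H]1CC[C@@H](C)[C@]2(C)Cc1c[nH]c2ccc(Br)cc12` carries bromo; in a functional assay on A549 cells (Homo sapiens) for inhibition, read by sulforhodamine B assay, with a stated time of 48 h (a lower number here means a stronger inhibitor of growth, a higher number a weaker inhibitor of growth), compound 1 gives 15000 nM. Compound 2 `COC(=O)[C@@]1(C)CCC=C2[C@@H]1CC[C@@H](C)[C@]2(C)Cc1c[nH]c2ccc(Cl)cc12` shows the change (chloro in place of bromo on an aromatic carbon), and in this assay compound 2 gives 16000 nM, a step of a 1.1-fold higher number from compound 1 to compound 2 (0.03 log units; within the scatter). Compound 3 `COC(=O)[C@@]1(C)CCC=C2[C@@H]1CC[C@@H](C)[C@]2(C)Cc1c[nH]c2c(Br)cccc12` carries bromo at a different place; the difference between the cores of compound 3 and compound 1 is not broken down here. In this assay compound 3 gives 22000 nM. Compound 4 `COC(=O)[C@@]1(C)CCC=C2[C@@H]1CC[C@@H](C)[C@]2(C)Cc1c[nH]c2c(Cl)cccc12` is not yet measured; it differs from compound 3 by chloro in place of bromo on an aromatic carbon. Going by the values given here, this is the same kind of change as the one from compound 1 to compound 2, though the places differ: in compound 2 the carbon is meta to a fused ring and para to a fused ring, while in compound 4 it is ortho to a fused ring and meta to a fused ring. Because the earlier swap moved the number only by a 1.1-fold higher number from compound 1 to compound 2 (0.03 log units; within the scatter), a similarly small step is expected here, a 1.1-fold higher number from compound 3 to compound 4 (0.04 log units; within the scatter). Compound 4 is therefore estimated at 24000 nM, with a likely range from 12000 nM to 48000 nM.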

Compound 4, concentration for 50% growth inhibition: 22000 nM
Compound 4: the middle estimate sits 1.1-fold (0.04 log units) above what was measured, and the stated range covers the measured number.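

The chloro for bromo swap gave no change at the digits printed from compound 3 to compound 4 (within the scatter) in this assay, so at this second place the halogen exchange again left the read-out where it was. Set side by side, the two swaps agree, which means that in this series the change carried over from one core to the other without a difference that can be told from scatter: the same change on two cores in this assay, a 1.1-fold higher number (0.03 log units; within the scatter) from compound 1 to compound 2 and no change at the digits printed (within the scatter) from compound 3 to compound 4, 1.1-fold (0.03 log units) apart, within the scatter of two such steps This is agreement between just two pairs, and both steps are within the scatter, which makes it an observation about these four compounds and not a rule for other cores in the series; it also gives no explanation of why the two halogens read alike.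

The compounds shown carry only bromo or chloro on the aromatic ring, which leaves open how an amine or a methoxy group at these places would read in this assay. Also open, as far as these compounds go, is whether a carboxylic acid in place of the ester on the shared core would move the number.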